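From 3-hydroxypropyl to 1-carboxyethyl on the amide

The source may hold more compounds than are shown below. What is called first, only, known or untested is meant among the compounds shown, and "the series" means these compounds.

compound 1 `CCn1c(C(=O)NCCNC(=O)OC(C)(C)C)ccc1C(CC)(CC)c1ccc(OCS(=O)(=O)c2ccccc2)c(C)c1`: > 50000 nM (a limit of the assay, not a number)
compound 2 `CCn1c(C(=O)N[C@H](C)CO)ccc1C(CC)(CC)c1ccc(OCS(=O)(=O)c2ccccc2)c(C)c1`: 10600 nM
compound 3 `CCn1c(C(=O)NCCCO)ccc1C(CC)(CC)c1ccc(OCS(=O)(=O)c2ccccc2)c(C)c1`: 42000 nM

In a functional assay on MCF7 cells (Homo sapiens) for antiproliferative activity, read by MTT assay, with a stated time of 24 h (a higher number here means a weaker inhibitor, a lower number a stronger inhibitor), compound 3 gives 42000 nM, the higher of the two actual numbers. Going by the values given here, the only other actual number belongs to compound 2, at 10600 nM. Compound 4 `CCn1c(C(=O)N[C@H](C)C(=O)O)ccc1C(CC)(CC)c1ccc(OCS(=O)(=O)c2ccccc2)c(C)c1` departs from compound 3 in one place: 1-carboxyethyl in place of 3-hydroxypropyl on an amide-type nitrogen. In short, 1-carboxyethyl stands in place of 3-hydroxypropyl on an amide-type nitrogen.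

The measured step that bears most on this is a 4.0-fold higher number from compound 2 to compound 3 (0.60 log units; beyond the scatter), with 3-hydroxypropyl in place of 1-(hydroxymethyl)ethyl on that same nitrogen. The steps of an at least 4.7-fold lower number from compound 1 to compound 2 (0.67 log units; beyond the scatter) and an at least 1.1-fold lower number from compound 1 to compound 3 (0.07 log units; that floor lies within the scatter) both start from a limit, so each gives only a floor. Among the compounds with values here, compound 4 gives up the 3-hydroxypropyl of compound 3, but no measured compound carries 1-carboxyethyl. A small move towards a lower number is therefore expected, smaller than a 4.0-fold higher number from compound 2 to compound 3 (0.60 log units; beyond the scatter) and possibly within the scatter. The expected step is a 1.7-fold lower number from compound 3 to compound 4 (0.23 log units; within the scatter). For compound 4 the estimate is 25000 nM, with an expected range from 8000 nM to 50000 nM.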

Compound 4, half-maximal inhibitory concentration: > 50000 nM
Compound 4: no number, only a limit; the forecaster's own chance of this, stated with the estimate: 35%; middle value at least 2.0-fold (0.30 log units) from the limit.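

In this assay compound 4 gives > 50000 nM, which is a limit of the assay and not a number. Where the two compounds differ only in carboxy against hydroxymethyl on the same saturated chain carbon, the result is an at least 4.7-fold higher number from compound 2 to compound 4 (0.67 log units; beyond the scatter), the first readable sign that the group on this chain carbon, and not only the chain shape, moves the reading at this amide-type nitrogen. The comparison with the 3-hydroxypropyl amide is less informative, at an at least 1.1-fold higher number from compound 3 to compound 4 (0.07 log units; that floor lies within the scatter), so compound 4 is not separated from that compound, and the step joining compound 1 and compound 4 cannot be read, with compound 4 now sharing the ceiling with compound 1: the limit of > 50000 nM in this assay, at which 2 of the 4 values shown sit.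

On these data alone, how far past that limit compound 4 lies remains unknown, so the size of the loss from the hydroxymethyl of compound 2 has only a floor. The compounds shown also leave open whether a methyl ester or an aminomethyl group on that same chain carbon would stay near compound 2 or fall to the limit with the carboxylic acid.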